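Epimer of a nitroaryl-derived acetamide at the ring carbon

The source may report more compounds than this note shows. Statements on the series, on what has been measured and on what is new or still open speak of the compounds shown alone.

Of the compounds shown here, two sharing one core have been measured in an assay on membranes from HEK293 cells for displacement of a labelled ligand from Neuronal acetylcholine receptor; alpha3/beta4 (Homo sapiens), with a stated time of 5 min; on this read-out lower numbers stand for stronger inhibition and higher numbers for weaker inhibition. Compound 1 `CN1CCC[C@H]1[C@@H]1COc2ccc([N+](=O)[O-])cc2O1` carries a nitro group on the aromatic ring; in this assay compound 1 gives 4500 nM. Compound 2 `CC(=O)Nc1ccc2c(c1)O[C@@H]([C@@H]1CCCN1C)CO2` carries an acetamide in place of the nitro group, and in this assay compound 2 gives 8700 nM. Compound 2 holds the higher of the two numbers, yet its gap to compound 1 lies within the usual scatter, so the two cannot be told apart.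

Compound 3 `CC(=O)Nc1ccc2c(c1)O[C@H]([C@@H]1CCCN1C)CO2` is the next step. How it differs from compound 2: the two compounds have the same atoms and bonds and differ only in configuration as drawn: 1 of 2 stereo elements differ; a stereocentre at a saturated ring carbon is drawn S in compound 2 and R in compound 3. Going by the values given here, no pair of measured compounds shows what such an inversion does on this core, so the account rests on compound 2 alone. In this assay the step of a 1.0-fold higher number from compound 2 to compound 3 (0.01 log units; within the scatter) is expected to stay within the scatter, with no clear direction. Compound 3 is therefore expected to give about 9000 nM, with a range from 2000 nM to 40000 nM.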

Compound 3, inhibition constant: 1900 nM
Compound 3: middle estimate off by 4.7-fold (0.68 log units), on the high side, and the stated range ends above it.
By their numbers in this assay, from the lowest: compound 3; then compounds 1 and 2 (each within the scatter of the next).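

In this assay, going by these compounds alone, the configuration at this saturated ring carbon matters on the shared core: going from S to R gives a 4.6-fold lower number from compound 2 to compound 3 (0.66 log units; beyond the scatter), a modest change that no earlier pair could show. That step can be assigned to this stereocentre alone because nothing else separates the two compounds: the fact that compounds 2 and 3 differ only in the configuration as drawn. Acetamido in place of nitro on an aromatic carbon now also comes with a 2.4-fold lower number from compound 1 to compound 3 (0.37 log units; beyond the scatter), although the two earlier values lay within the scatter of each other.

On these data alone, whether the same inversion has a similar effect with nitro on the aromatic ring remains open, as does the effect of changing the second stereo element. It is also unknown whether an amine or a carboxylic acid in place of the acetamide would retain the value seen with the R configuration.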